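Amide nitrogen swap on the shared core of compound 1

The source may hold more compounds than are shown below. What is called first, only, known or untested is meant among the compounds shown, and "the series" means these compounds.

Going by the values given here, compound 1 `COc1ccc(CNC(=O)c2nc(Br)c3cccnc3c2N[C@H]2CC[C@H](N)CC2)cc1` is the only member of the series with a number in a functional assay on MDA-MB-435 cells (Homo sapiens) for cytotoxicity, read by MTT assay, with a stated time of 72 h; on this read-out higher numbers stand for weaker inhibition and lower numbers for stronger inhibition: compound 1 gives 5000 nM. Compound 2 `O=C(NCc1ccc(F)cc1)c1nc(Br)c2cccnc2c1NCCO` gives only a limit of the assay in this assay, compound 2 sitting at > 20000 nM. The other entry shown is therefore (the limit of > 20000 nM in this assay, at which 1 of the 2 values shown sits), and compound 1 stands as the sole measured value against which any new compound can be set.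

Compound 3 `N[C@H]1CC[C@H](Nc2c(C(=O)Nc3ccccc3)nc(Br)c3cccnc23)CC1` is not yet measured. It differs from compound 1 in one place: phenyl in place of 4-methoxybenzyl on an amide-type nitrogen. Among the compounds with values here, no step between two measured compounds is recorded in this assay, so the size of such a change cannot be read from the series itself; compound 2 and compound 1 differ in more than one place, and compound 2 shows only a limit.

The step from compound 1 to compound 3 is expected to be a 1.6-fold higher number from compound 1 to compound 3 (0.20 log units; within the scatter), a modest move toward weaker inhibition that may not exceed the usual scatter. Compound 3 is estimated at 8000 nM, with an expected range from 2500 nM to 25000 nM.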

Compound 3, half-maximal inhibitory concentration: 1000 nM
The estimate for compound 3 lay 8.0-fold (0.90 log units) above the measured number, and the stated range ends above it.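

Phenyl in place of 4-methoxybenzyl on the amide-type nitrogen gives a 5.0-fold lower number from compound 1 to compound 3 (0.70 log units; beyond the scatter) in this assay, the first step in the series that can be read at this position, and it lies beyond the scatter. The group on this nitrogen therefore affects the read-out in this assay, and the 4-methoxybenzyl group, with its 9 heavy atoms and 1 hydrogen-bond acceptor, is not needed to keep a measurable number: phenyl, with 6 heavy atoms and no hydrogen-bond acceptor, gives a lower one on the same core. Nothing measured on these compounds speaks to why the number falls, and the one limit in the series does not bear on this step.

The change removes the methoxy group and shortens the link from the ring to the nitrogen in a single step, so the compounds shown cannot assign the step to either part; plain benzyl and 4-methoxyphenyl on the same nitrogen would separate the two. Also open, as far as these compounds go, is how far this nitrogen tolerates other groups, such as a longer phenethyl chain or a phenyl ring carrying a carboxylic acid.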